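Working notes on cytotoxicity in a small series of four

A few compounds are considered here, and "the series" means these few. Any claim that something is new, unique, unknown or untested is made for them only; others in the source may bear on it.

Measured in an ADME assay on THP-1 cells (Homo sapiens) for cytotoxicity (on this read-out higher numbers stand for weaker inhibition and lower numbers for stronger inhibition), so far:
- compound 1 `COc1ccccc1-c1nnc(-c2ccc(C(=O)N/N=C/c3cccc(F)c3)cc2)o1` gives 353000 nM
- compound 2 `COc1ccccc1-c1nnc(-c2ccc(C(=O)N/N=C/c3ccc(O)c(O)c3)cc2)o1` gives 100000 nM
- compound 3 `COc1ccccc1-c1nnc(-c2ccc(C(=O)N/N=C/c3ccc(Cl)cc3Cl)cc2)o1` gives 78800 nM

Compound 3 sits at the low end of the three numbers, but only part of that is firm: a 4.5-fold lower number from compound 1 to compound 3 (0.65 log units; beyond the scatter) is beyond the scatter, while a 1.3-fold lower number from compound 2 to compound 3 (0.10 log units; within the scatter) is within it, so compounds 2 and 3 cannot be ranked against each other on this assay.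

The next compound, compound 4 `COc1ccc(/C=N/NC(=O)c2ccc(-c3nnc(-c4ccccc4OC)o3)cc2)cc1O`, is not yet measured. It differs from compound 3 in one place: 3-hydroxy-4-methoxyphenyl in place of 2,4-dichlorophenyl on a carbon with a double bond to nitrogen. For the measured compounds named here, two measured steps bear on this. a 3.5-fold lower number from compound 1 to compound 2 (0.55 log units; beyond the scatter) brought in a ring carrying hydroxy groups, and a 1.3-fold lower number from compound 2 to compound 3 (0.10 log units; within the scatter) swapped that ring for the dichlorinated one with no change beyond the scatter. The entering group in compound 4 keeps one hydroxy and adds a methoxy, so it stands nearer to compound 2 than to compound 3 in kind.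

For compound 4 the expectation is therefore no step beyond the scatter in this assay, with at most a slight rise toward the number of compound 2. This rests on compound 2 giving 100000 nM and on compound 3 giving 78800 nM, two numbers that lie within the scatter of each other. The expected step is a 1.4-fold higher number from compound 3 to compound 4 (0.14 log units; within the scatter). Compound 4 is estimated at 110000 nM, in a range from 50000 nM to 250000 nM.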

Compound 4, half-maximal inhibitory concentration: 260000 nM
For compound 4 the middle estimate is 2.4-fold (0.37 log units) below the measured one; the measured number lies above the stated range.
By their numbers in this assay, from the lowest: compounds 3 and 2 (each within the scatter of the next); then compounds 4 and 1 (each within the scatter of the next).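

In this assay, this position on a carbon with a double bond to nitrogen proves sensitive to a small edit: methyl in place of hydrogen on an oxygen on an aromatic ring gives a 2.6-fold higher number from compound 2 to compound 4 (0.41 log units; beyond the scatter). The 3-hydroxy-4-methoxyphenyl group also parts from 2,4-dichlorophenyl, with a 3.3-fold higher number from compound 3 to compound 4 (0.52 log units; beyond the scatter), yet it cannot be told apart from 3-fluorophenyl, with a 1.4-fold lower number from compound 1 to compound 4 (0.13 log units; within the scatter). Keeping a hydroxy group is therefore no guide here: among these compounds, compound 4 falls with compound 1 rather than with compound 2.

From the compounds shown here alone, whether the step follows the methyl on the oxygen alone stays open, as does how an amine, a carboxylic acid or a longer chain on that oxygen would read. No evidence on the cause of these steps is at hand.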